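Replacing pyridinyl with methylphenyl on a weakly cytotoxic core

The source may report more compounds than this note shows. Statements on the series, on what has been measured and on what is new or still open speak of the compounds shown alone.

Compound 1 `Clc1ccc(-c2cc(-c3cccnc3)nc(-c3cccs3)c2)o1` gives 22300 nM in a functional assay on K562 cells (Homo sapiens) for cytotoxicity, in the presence of a further agent that is not named here (on this read-out lower numbers stand for stronger inhibition and higher numbers for weaker inhibition), the highest number of the three shown, though all three sit within the scatter of one another: compound 3 `Clc1ccc(-c2cc(-c3cccnc3)nc(-c3ccsc3)c2)o1` gives 21700 nM and compound 2 `Clc1ccc(-c2cc(-c3ccc(Cl)o3)cc(-c3ccsc3)n2)cc1` gives 18700 nM. Compound 4 `Cc1ccc(-c2cc(-c3ccc(Cl)o3)cc(-c3cccs3)n2)cc1` differs from compound 1 by 4-methylphenyl in place of pyridin-3-yl on an aromatic carbon. Among the measured compounds shown here, two measured steps bear on this. The step of a 1.2-fold higher number from compound 2 to compound 3 (0.06 log units; within the scatter) shows that swapping a pyridin-3-yl for a carbon-only ring barely moved the number, and a 1.0-fold lower number from compound 1 to compound 3 (0.01 log units; within the scatter) shows that the thiophene attachment barely moved it either, which connects compound 2 to compound 4. No step beyond the scatter is therefore expected in this assay. Compound 4 is expected to give 20000 nM, between 8000 nM and 50000 nM, which means a 1.1-fold lower number from compound 1 to compound 4 (0.05 log units; within the scatter).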

Compound 4, half-maximal inhibitory concentration: 21500 nM
For compound 4 the middle estimate is 1.1-fold (0.03 log units) below the measured one; low and high end bracket the measured number.
By their numbers in this assay, from the lowest: compounds 2, 4, 3 and 1 (each within the scatter of the next).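

With thiophen-2-yl on the shared core, 4-methylphenyl in place of pyridin-3-yl next to the ring nitrogen gives a 1.0-fold lower number from compound 1 to compound 4 (0.02 log units; within the scatter) in this assay. The earlier exchange at this position paired pyridin-3-yl with 4-chlorophenyl on the thiophen-3-yl compounds, so this result extends the same within-scatter outcome to a different thiophene attachment and a methyl-bearing ring. No measurement shown here accounts for this outcome. The compounds leave open whether an amine or a carboxylic acid on this ring would give a step beyond the scatter. They also leave open whether any such step would depend on the thiophene attachment.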